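Swapping a Hydroxycyclohexyl for a Carbamoylcyclobutyl

The source may report more compounds than this note shows. Statements on the series, on what has been measured and on what is new or still open speak of the compounds shown alone.

Three compounds share one core and differ only in the saturated ring attached to a nitrogen on an aromatic ring. In an assay on isolated protein for inhibition of protein kinase C delta type (Homo sapiens), read by TR-FRET, with a stated time of 2 h (a lower number here means a stronger inhibitor, a higher number a weaker inhibitor), compound 1 `N#Cc1cnc(NCc2cnccc2C(F)(F)F)cc1N[C@H]1CC[C@H](O)CC1` gives 6500 nM, compound 2 `N#Cc1cnc(NCc2cnccc2C(F)(F)F)cc1N[C@H]1CC[C@@H](C(N)=O)CC1` gives 400 nM, and compound 3 `CC1(C)C[C@H](Nc2cc(NCc3cnccc3C(F)(F)F)ncc2C#N)CC[C@H]1O` gives 2200 nM. Compound 3 thus stands second highest of the three: a 3.0-fold lower number from compound 1 to compound 3 (0.47 log units; beyond the scatter), while a 5.5-fold higher number from compound 2 to compound 3 (0.74 log units; beyond the scatter). As far as these compounds go, compound 4 `CC1(C)[C@@H](Nc2cc(NCc3cnccc3C(F)(F)F)ncc2C#N)C[C@H]1C(N)=O` is untested; it carries 3-carbamoyl-2,2-dimethylcyclobutyl in place of 4-hydroxy-3,3-dimethylcyclohexyl on a nitrogen on an aromatic ring. The measured step that bears on this is a 16-fold lower number from compound 1 to compound 2 (1.21 log units; beyond the scatter), where a hydroxyl gave way to a carbamoyl on an otherwise unchanged ring. Within the data shown here, no measured pair shows a six-membered ring shrinking to a four-membered one, so that part is uncharted. For compound 4 the expected step is a 3.7-fold lower number from compound 3 to compound 4 (0.56 log units; beyond the scatter). Compound 4 is estimated at 600 nM, within 150 nM to 2500 nM.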

Compound 4, half-maximal inhibitory concentration: 4500 nM
Compound 4: the middle estimate sits 7.5-fold (0.88 log units) below what was measured; the whole stated range lies below it.
By their numbers in this assay, from the lowest: compound 2; then compound 3; then compounds 4 and 1 (each within the scatter of the next).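

The carbamoyl group that went with the lowest number on the six-membered ring does not keep that standing on the 3-carbamoyl-2,2-dimethylcyclobutyl ring (an 11-fold higher number from compound 2 to compound 4 (1.05 log units; beyond the scatter)). Carrying a carbamoyl is therefore not enough by itself at this position: the change from the hydroxyl-bearing dimethyl ring also gives a weaker number (a 2.0-fold higher number from compound 3 to compound 4 (0.31 log units; beyond the scatter)), and the result sits within the scatter of the plain hydroxycyclohexyl (a 1.4-fold lower number from compound 1 to compound 4 (0.16 log units; within the scatter)).

As far as these compounds go, compound 4 differs from compound 2 in both ring size and the two added methyl groups, so the share of each remains open. Also open is how a cyclobutyl ring carrying an amine or a carboxylic acid would behave, and nothing shown here explains the result.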